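The source may hold more compounds than are shown below. What is called first, only, known or untested is meant among the compounds shown, and "the series" means these compounds.

Compound 1 `O=C(c1ccc(CN2C(=O)c3ccccc3S2(=O)=O)cc1)N1CCCCC1` gives 69200 nM in an ADME assay on RAW264.7 cells (Mus musculus) for cytotoxicity, read by WST assay; a higher number here means that more compound is tolerated, a lower number that less compound is tolerated. Compound 2 `CNC(=O)c1ccc(CN2C(=O)c3ccccc3S2(=O)=O)cc1` gives > 100000 nM, which is a limit of the assay rather than a number.

Compound 2 therefore stands only at a limit in this assay; it sits at the limit of > 100000 nM in this assay, at which 1 of the 2 values shown sits. Compound 3 `CN(C(=O)OC(C)(C)C)C(=O)c1ccc(CN2C(=O)c3ccccc3S2(=O)=O)cc1` differs from compound 2 by tert-butoxycarbonyl in place of hydrogen on an amide-type nitrogen. For the measured compounds named here, the one measured step, an at least 1.4-fold higher number from compound 1 to compound 2 (0.15 log units; that floor lies within the scatter), also touched the amide end but stayed within the scatter. Compound 3 is therefore expected to stay near the edge of this assay, a step of an at least 1.4-fold lower number from compound 2 to compound 3 (0.15 log units; that floor lies within the scatter) being the estimate. The expected value for compound 3 is 70000 nM, ranging from 25000 nM to 150000 nM.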

Compound 3, concentration lethal to 50% of the cells: > 100000 nM
Compound 3: only a limit was reported (the forecaster's own chance of this, stated with the estimate: 45%); middle value at least 1.4-fold (0.15 log units) away from the limit.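

In this assay compound 3 gives > 100000 nM, which is a limit of the assay and not a number. With tert-butoxycarbonyl on the amide-type nitrogen, compound 3 sits at the same limit as compound 2, so the step between them cannot be read. In place of piperidin-1-yl on a carbonyl carbon, methyl(tert-butoxycarbonyl)amino gives an at least 1.4-fold higher number from compound 1 to compound 3 (0.15 log units; that floor lies within the scatter), and the limit now holds most of the compounds shown: the limit of > 100000 nM in this assay, at which 2 of the 3 values shown sit.

On these data alone, what stays open is whether an amine or a carboxylic acid on this nitrogen, or a longer chain, would give a readable value.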